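Swapping the benzyl substituent of a coumarin-type CYP11B1 inhibitor

The source may hold more compounds than are shown below. What is called first, only, known or untested is meant among the compounds shown, and "the series" means these compounds.

Measured so far:
- compound 1, `O=c1cc(Cn2ccnc2)c2ccc(OCc3cccc(C(F)(F)F)c3)cc2o1`, giving 20 nM in an assay on V79MZh11B1 cells for inhibition of cytochrome P450 11B1, mitochondrial (Homo sapiens), read by HPLC, with a stated time of 25 min; on this read-out lower numbers stand for stronger inhibition and higher numbers for weaker inhibition
- compound 2, `O=c1cc(Cn2ccnc2)c2ccc(OCc3cccc(Cl)c3)cc2o1`, giving 31 nM in this assay
- compound 3, `COc1ccc(COc2ccc3c(Cn4ccnc4)cc(=O)oc3c2)cc1`, giving 80 nM in this assay

Compound 3 stands at the highest number of the three, so it is the weakest inhibitor of this small set. The nearest to it is compound 2, and the change from one to the other is a 2.6-fold higher number from compound 2 to compound 3 (0.41 log units; beyond the scatter). Compound 1 lies further away still, and its step to compound 2, a 1.6-fold higher number from compound 1 to compound 2 (0.19 log units; within the scatter), is within the scatter.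

The unmeasured compound 4, `Cc1cccc(COc2ccc3c(Cn4ccnc4)cc(=O)oc3c2)c1`, differs from compound 3 by 3-methylphenyl in place of 4-methoxyphenyl on a saturated chain carbon bound to an oxygen on an aromatic ring. Going by the values given here, the step that bears on this directly is the one between compound 2 and compound 3, where the 4-methoxyphenyl arrived and the number rose modestly. Removing the 4-methoxyphenyl again, now for a 3-methylphenyl, is therefore expected to bring the number back down by roughly that amount, estimated as a 2.0-fold lower number from compound 3 to compound 4 (0.30 log units; within the scatter). Compound 4 is thus expected to give about 40 nM in this assay, within a range from 15 nM to 100 nM.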

Compound 4, half-maximal inhibitory concentration: 45 nM
Compound 4: middle estimate off by 1.1-fold (0.05 log units), on the low side, within the range that was stated.
By their numbers in this assay, from the lowest: compounds 1, 2, 4 and 3 (each within the scatter of the next, the first and the last beyond it).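

Replacing 4-methoxyphenyl with 3-methylphenyl gives a 1.8-fold lower number from compound 3 to compound 4 (0.25 log units; within the scatter), so in this assay this change cannot be told apart from the ordinary variation between repeat measurements. Methyl in place of chloro is just as unresolved, with a 1.5-fold higher number from compound 2 to compound 4 (0.16 log units; within the scatter), so compound 4 cannot be separated from either compound 2 or compound 3, even though those two are separated from each other. Methyl in place of trifluoromethyl gives a 2.3-fold higher number from compound 1 to compound 4 (0.35 log units; beyond the scatter), so among trifluoromethyl, chloro and methyl on this aromatic carbon, only the trifluoromethyl and methyl pair is told apart, and only modestly.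

The swap from 4-methoxybenzyl to 3-methylbenzyl alters both the group and the number in its name, and a 3-methoxyphenyl or 4-methylphenyl group would be needed to tell those two changes apart. No available measurement gives a reason for any of these differences.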